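The source may report more compounds than this note shows. Statements on the series, on what has been measured and on what is new or still open speak of the compounds shown alone.

Measured so far in an assay on isolated protein for inhibition of Amine oxidase [flavin-containing] B (Homo sapiens), read by fluorescence, with a stated time of 20 min; on this read-out higher numbers stand for weaker inhibition and lower numbers for stronger inhibition: compound 1 `C/C(CC(C)C)=N/Nc1nc(-c2cccc([N+](=O)[O-])c2)cs1` gives 12 nM; compound 2 `C=CCC/C(C)=N\Nc1nc(-c2cccc([N+](=O)[O-])c2)cs1` gives 101 nM. Compound 2 stands at the highest of the two numbers, with compound 1 the nearest at the lower number, by the step of an 8.4-fold higher number from compound 1 to compound 2 (0.93 log units; beyond the scatter). Compound 3 `CCCCCC/C(C)=N\Nc1nc(-c2cccc([N+](=O)[O-])c2)cs1` differs from compound 2 by butyl in place of vinyl on a saturated chain carbon, two bonds along the chain from a carbon with a double bond to nitrogen. Among the compounds with values here, the only measured step, from compound 1 to compound 2, swaps a branched for an unsaturated linear chain and does not directly cover a chain extension, so a step no larger than the scatter is expected, a 1.5-fold higher number from compound 2 to compound 3 (0.17 log units; within the scatter). Compound 3 is estimated at 150 nM, within 40 nM to 600 nM.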

Compound 3, half-maximal inhibitory concentration: 626 nM
The estimate for compound 3 lay 4.2-fold (0.62 log units) below the measured number, and the stated range ends below it.
By their numbers in this assay, from the lowest: compound 1; then compound 2; then compound 3.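

In this assay, butyl in place of vinyl is not a neutral change at this place: a 6.2-fold higher number from compound 2 to compound 3 (0.79 log units; beyond the scatter), beyond the scatter, so the chain here responds to this change. Pentyl in place of isopropyl gives the largest step shown, a 52-fold higher number from compound 1 to compound 3 (1.72 log units; beyond the scatter), and among these compounds the hexyl chain of compound 3 carries the highest number. Nothing measured bears on the origin of these steps.

This change both lengthens the chain and removes its double bond, and the compounds shown do not separate the two. On these data alone, whether a longer chain, or an amine or carboxylic acid at the chain end, would move the number remains open.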